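Imidazole amide in place of aryl amide: cytotoxicity outlook

The source may report more compounds than this note shows. Statements on the series, on what has been measured and on what is new or still open speak of the compounds shown alone.

The three measured compounds share one core and differ only in the group on the carbonyl carbon of the amide. Compound 1 `COc1ccc(-c2cnc(NC(=O)c3cccc(Br)c3)n2C)cc1` carries 3-bromophenyl there. In a toxicity assay on THP-1 cells (Homo sapiens) for inhibition (on this read-out higher numbers stand for lower toxicity in this test and lower numbers for higher toxicity in this test), compound 1 gives > 100000 nM, which is a limit of the assay and not a number. Compound 2 `CCC(=O)Nc1ncc(-c2ccc(OC)cc2)n1C` carries ethyl. In this assay compound 2 gives > 100000 nM, again a limit. Compound 3 `COc1ccc(-c2cnc(NC(=O)c3ccc(C)cc3)n2C)cc1` carries 4-methylphenyl. In this assay compound 3 gives > 100000 nM, also a limit. All three values sit at the limit of > 100000 nM in this assay, at which 3 of the 3 values shown sit. Among the compounds with values here, the steps a step that the two limits leave unreadable from compound 1 to compound 2, a step that the two limits leave unreadable from compound 1 to compound 3 and a step that the two limits leave unreadable from compound 2 to compound 3 therefore have no readable size; two limits give no step that can be measured.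

Compound 4 `COc1ccc(-c2cnc(NC(=O)c3ncc[nH]3)n2C)cc1` is not yet measured. Its change from compound 3: 1H-imidazol-2-yl in place of 4-methylphenyl on a carbonyl carbon. Within the data shown here, no measured step bears on this change with a readable size. What the series shows is only that 3-bromophenyl, ethyl and 4-methylphenyl on the carbonyl carbon all leave the compound at the limit in this assay. The expectation is that compound 4 likewise returns a limit, with a step that the limit leaves unreadable from compound 3 to compound 4 of no readable size. Compound 4 is estimated at 150000 nM, within a range of 60000 nM to 400000 nM.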

Compound 4, half-maximal cytotoxic concentration: > 100000 nM
Compound 4 was reported as a limit; the forecaster's own chance of this, stated with the estimate: 85%; the middle value is on the limit's open side.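

In this assay compound 4 gives > 100000 nM, a limit of the assay and not a number. No step from compound 1, compound 2 or compound 3 to compound 4 can be read, and the series stays flat at one bound: the limit of > 100000 nM in this assay, at which 4 of the 4 values shown sit.

The compounds shown leave open whether any group on the carbonyl carbon gives a readable value in this assay.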